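The source may hold more compounds than are shown below. What is called first, only, known or untested is meant among the compounds shown, and "the series" means these compounds.

Measured so far in a functional assay on SF-295 cells (Homo sapiens) for inhibition, read by sulforhodamine B assay, with a stated time of 48 h, tested at 10 uM; a lower number here means less inhibition, a higher number more inhibition at the concentration tested (going by the name of the read-out):
compound 1, `O=Cc1ccc(-c2cn3ccnc3c(-c3ccc4ncn(C5CCCCC5)c4c3)n2)cc1`: 23.1%
compound 2, `c1ccc2c(-c3cn4ccnc4c(-c4ccc5ncn(C6CCCCC6)c5c4)n3)cccc2c1`: 6.34%

Compound 2 stands at the lower of these two numbers. Within the data shown here, the nearest measured neighbour is compound 1, which in this assay gives 23.1%, and the one measured step, a number 16.8 percentage points lower from compound 1 to compound 2 (beyond the scatter), is beyond the scatter but modest in size.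

Compound 3, `Brc1ccc(-c2cn3ccnc3c(-c3ccc4ncn(C5CCCCC5)c4c3)n2)cc1`, has not been measured yet. Its change from compound 2 is 4-bromophenyl in place of naphthalen-1-yl on an aromatic carbon. Among the measured compounds shown here, the same position is the one altered in the step from compound 1 to compound 2, so that step is the only guide to what a change of the group here can do: a modest shift, with a smaller single-ring group at this place giving the higher number. The entering 4-bromophenyl is again a single-ring group, so compound 3 is expected to move back toward compound 1 rather than to fall further; the step of a number 9.7 percentage points higher from compound 2 to compound 3 (within the scatter) is the expected size. In this assay compound 3 is therefore estimated at 16%, within a range from 2% to 32%.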

Compound 3, a percentage reported as inhibition, at one concentration (the size of the read-out at that concentration, not a potency): 41.3%
Estimate against measurement, compound 3: 25.3 percentage points below; the measured number lies above the stated range.
By their numbers in this assay, from the lowest: compound 2; then compound 1; then compound 3.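

In this assay, this position proves more sensitive than the first step suggested: there is a number 35 percentage points higher from compound 2 to compound 3 (beyond the scatter) when 4-bromophenyl replaces naphthalen-1-yl, a large change that reverses the direction the earlier pair might have implied for a single-ring group. The number of rings alone does not set the result, since compound 1 and compound 3 both carry one ring here and still differ, with a number 18.2 percentage points higher from compound 1 to compound 3 (beyond the scatter) when bromo replaces formyl on that ring. The group carried on the ring therefore matters as well, and among these three compounds compound 3 gives the most inhibition at the concentration tested. No measurement available here explains why these groups differ in this way.

From the compounds shown here alone, it remains open whether the rise is particular to bromo or would also appear with another group in its place, such as an amine, a carboxylic acid or a methoxy group. These are also readings at a single concentration, so they leave open how the compounds would rank in potency across a range of concentrations.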